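The compounds below may be only part of what the source reports. "The series", "measured", "known", "first", "only" and "open" are said of these compounds alone.

Compound 2 `O=C(CN1CCC(c2cccc[n+]2[O-])CC1)NC1CCCCC1` gives 294 nM in a functional assay on HEK293 cells for agonist activity at D(4) dopamine receptor (Homo sapiens), read by FLIPR (on this read-out lower numbers stand for an effect already at smaller amounts and higher numbers for an effect only at larger amounts of compound), the highest of the two numbers measured; compound 1 `O=C(CN1CCC(c2cccc[n+]2[O-])CC1)Nc1ccc(F)cc1F` gives 103 nM. Going by the values given here, the one measured step bears directly on the change at hand: a 2.9-fold higher number from compound 1 to compound 2 (0.46 log units; beyond the scatter). Compound 3 `O=C(CN1CCC(c2cccc[n+]2[O-])CC1)Nc1ccc(F)cc1` differs from compound 2 by 4-fluorophenyl in place of cyclohexyl on an amide-type nitrogen, largely reversing that step. A lower number for compound 3 in this assay is therefore expected, of roughly the size seen before, so that a 2.5-fold lower number from compound 2 to compound 3 (0.39 log units; beyond the scatter) is estimated. Compound 3 is expected to give about 120 nM, within 50 nM to 300 nM.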

Compound 3, half-maximal effective concentration: 85 nM
Beside the measured number, compound 3's estimate is 1.4-fold (0.15 log units) above it; the measured number falls inside the stated range.
By their numbers in this assay, from the lowest: compounds 3 and 1 (each within the scatter of the next); then compound 2.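

With a 3.5-fold lower number from compound 2 to compound 3 (0.54 log units; beyond the scatter) in this assay, the change from cyclohexyl to 4-fluorophenyl on the amide-type nitrogen shows that the gap to cyclohexyl is not confined to 2,4-difluorophenyl, as both aromatic groups now give lower numbers than cyclohexyl. Hydrogen in place of fluoro on an aromatic carbon, with a 1.2-fold lower number from compound 1 to compound 3 (0.08 log units; within the scatter), stays within the scatter, so this pair separates the two aromatic groups by no reliable margin. Nothing available explains either result. The compounds shown leave open how a benzyl group or a pyridyl ring on that nitrogen would compare. They also leave open whether chloro or methoxy could replace fluoro on the aromatic ring without shifting the number.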